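The source may hold more compounds than are shown below. What is called first, only, known or untested is meant among the compounds shown, and "the series" means these compounds.

Compound 1 `CCc1cc(Br)ccc1Nc1ncnc2cc(OC)c(OCCCN3CCNCCNCCNCC3)cc12`: > 50000 nM (a limit of the assay, not a number)
Compound 2 `COc1cc2ncnc(Nc3ccc(F)c(Br)c3)c2cc1OCCCN1CCNCCNCC1`: 34300 nM
Compound 3 `COc1cc2ncnc(Nc3ccc(Cl)c(C(F)(F)F)c3)c2cc1OCCCN1CCNCCNCC1`: 6230 nM
Compound 4 `CCc1cc(Br)ccc1Nc1ncnc2cc(OC)c(OCCCN3CCNCCNCC3)cc12`: not yet measured

All of these results come from a functional assay on A549 cells (Homo sapiens) for antiproliferative activity, read by MTT assay, with a stated time of 72 h; a higher number here means a weaker inhibitor, a lower number a stronger inhibitor. Among the measured compounds shown here, compound 3 gives 6230 nM, the lower of the two true numbers so far, and compound 2 gives 34300 nM. Compound 1 reached only a limit, > 50000 nM.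

Compound 4 changes compound 3 in one place: 4-bromo-2-ethylphenyl in place of 4-chloro-3-(trifluoromethyl)phenyl on a nitrogen on an aromatic ring. For the measured compounds named here, one measured step concerns this same place: a 5.5-fold lower number from compound 2 to compound 3 (0.74 log units; beyond the scatter). It shows that exchanging this group can shift the number beyond the scatter, and that 4-chloro-3-(trifluoromethyl)phenyl was the better of the two groups compared. The entering group also occurs in compound 1, whose result is the limit > 50000 nM, though that compound differs elsewhere too. A rise of similar size to the measured step therefore seems likely, with wide uncertainty. The estimated change is a 3.5-fold higher number from compound 3 to compound 4 (0.55 log units; beyond the scatter). For compound 4 the expected value is 22000 nM, with an estimated range of 7000 nM to 60000 nM.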

Compound 4, half-maximal inhibitory concentration: > 50000 nM
Compound 4 was reported as a limit (the forecaster's own chance of this, stated with the estimate: 25%); middle value at least 2.2-fold (0.35 log units) away from the limit.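

In this assay, the group on this nitrogen can by itself move the result well beyond the scatter: 4-bromo-2-ethylphenyl in place of 4-chloro-3-(trifluoromethyl)phenyl gives an at least 8.0-fold higher number from compound 3 to compound 4 (0.90 log units; beyond the scatter). The comparison with the other measured group gives an at least 1.4-fold higher number from compound 2 to compound 4 (0.16 log units; that floor lies within the scatter), and with a floor inside the scatter, it does not set 4-bromo-2-ethylphenyl apart from 3-bromo-4-fluorophenyl. Compound 1 and compound 4 both carry 4-bromo-2-ethylphenyl and both end at a limit of the assay, leaving the step between them unreadable: the limit of > 50000 nM in this assay, at which 2 of the 4 values shown sit.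

On these data alone, the true number for compound 4 remains unknown, and with it the full size of its steps. Also open, as far as these compounds go, is whether 4-chlorophenyl or unsubstituted phenyl on the same nitrogen would match compound 3 or fall away as compound 4 does.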